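Swapping Chloro for Ethyl at the Assay Limit

The source may report more compounds than this note shows. Statements on the series, on what has been measured and on what is new or still open speak of the compounds shown alone.

Of the compounds shown here, three sharing one core have been tested in an ADME assay on HEK293 cells (Homo sapiens) for cytotoxicity, read by MTT assay, with a stated time of 44 h; on this read-out higher numbers stand for weaker inhibition and lower numbers for stronger inhibition. Compound 1 `CC1(c2ccccn2)ON=C(c2cccc(Cl)c2)O1` gives > 100000 nM, which is a limit of the assay rather than a number. Compound 2 `Clc1ccc(C2=NOC(c3ccc(Cl)c(Cl)c3)O2)cc1` likewise gives only a limit, > 100000 nM. Compound 3 `Clc1ccc(C2=NOC(c3ccc(Cl)cc3)O2)cc1` also reaches only the limit, > 100000 nM. Within the data shown here, the single step between measured compounds, a step that the two limits leave unreadable from compound 2 to compound 3, cannot be read in size, because both of its ends sit at the limit of > 100000 nM in this assay, at which 3 of the 3 values shown sit. Compound 3 therefore stands at the limit alongside the other two, and nothing separates the three on the numbers shown.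

Compound 4 `CCc1ccc(C2ON=C(c3ccc(Cl)cc3)O2)cc1` differs from compound 3 by ethyl in place of chloro on an aromatic carbon. Among the measured compounds shown here, no measured step resembles this change, and the only recorded step is unreadable, so the expectation rests on the fact that every value so far sits at the same limit. Compound 4 is therefore expected to remain at or beyond that limit, with an estimate of 200000 nM and a range from 50000 nM to 1000000 nM. The step expected, a step that the limit leaves unreadable from compound 3 to compound 4, would most likely again end in a reported limit rather than a measurable number, in line with compound 3 and (the limit of > 100000 nM in this assay, at which 3 of the 3 values shown sit).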

Compound 4, half-maximal inhibitory concentration: > 100000 nM
Compound 4: only a limit was reported (the forecaster's own chance of this, stated with the estimate: 85%); the middle value is on the limit's open side.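

No size can be read for the step between compound 3 and compound 4, because both compounds report only a limit: the limit of > 100000 nM in this assay, at which 4 of the 4 values shown sit.

The compounds shown leave open how far each one's true value lies past that limit, and so whether ethyl in place of chloro changes the result in this assay at all.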